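This account rests on a few compounds, and the source may have more. Where it says the series, first, only, none or still open, it means among the compounds named here.

Working notes on the series

Three compounds have been run in an ADME assay on HEK293 cells (Homo sapiens) for cytotoxicity, read by MTT assay, with a stated time of 48 h; a higher number here means a weaker inhibitor, a lower number a stronger inhibitor. Compound 1 `CN(C)CCn1c(N)c(-c2nc3ccccc3[nH]2)c2nc(C#N)c(C#N)nc21` gives 9730 nM. Compound 2 `CN(C)CCCn1c(N)c(-c2nc3ccccc3[nH]2)c2nc(C#N)c(C#N)nc21` gives 8360 nM. Compound 3 `CN(C)CCCn1c(N)c(-c2nc3ccccc3s2)c2nc(C#N)c(C#N)nc21` gives 4290 nM.

The move from compound 1 to compound 2 is the chain change (dimethylamino)methyl in place of dimethylamino on a saturated chain carbon, two bonds along the chain from an aromatic nitrogen and produces a 1.2-fold lower number from compound 1 to compound 2 (0.07 log units; within the scatter). The move from compound 2 to compound 3 swaps one ring system for another and produces a 1.9-fold lower number from compound 2 to compound 3 (0.29 log units; within the scatter). Compound 3 has the lowest number of the three, but its gap to compound 2 sits within the scatter, so no order between these two is claimed; only the gap from compound 1 to compound 3 lies beyond the scatter. How the core of compound 1 and the core of compound 3 differ is not broken down here.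

Compound 4 `CN(C)CCCCn1c(N)c(-c2nc3ccccc3s2)c2nc(C#N)c(C#N)nc21` is not yet measured. It differs from compound 3 by (dimethylamino)methyl in place of dimethylamino on a saturated chain carbon, three bonds along the chain from an aromatic nitrogen. Within the data shown here, this is the same kind of change as the one from compound 1 to compound 2, though the place is not the same: there the insertion sits two bonds along the chain from an aromatic nitrogen, here three bonds along the chain from an aromatic nitrogen.

The step from compound 3 to compound 4 in this assay is expected to be about a 1.2-fold lower number from compound 3 to compound 4 (0.08 log units; within the scatter), set beside the earlier chain extension, which rests on compound 1 to compound 2 giving a 1.2-fold lower number from compound 1 to compound 2 (0.07 log units; within the scatter), a step within the scatter. Compound 4 is therefore estimated at 3600 nM, with a range from 1500 nM to 8500 nM.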

Compound 4, half-maximal inhibitory concentration: 5310 nM
Estimate against measurement, compound 4: 1.5-fold (0.17 log units) below, and the stated range covers the measured number.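

In this assay, the same chain extension on the core of compound 3, read here as 3-(dimethylamino)propyl to 4-(dimethylamino)butyl, gives a 1.2-fold higher number from compound 3 to compound 4 (0.09 log units; within the scatter), so no order between these two compounds is claimed. Set beside the step on the other core, the two readings of the change do not differ beyond the scatter: the same change on two cores in this assay, a 1.2-fold lower number (0.07 log units; within the scatter) from compound 1 to compound 2 and a 1.2-fold higher number (0.09 log units; within the scatter) from compound 3 to compound 4, 1.4-fold (0.16 log units) apart, within the scatter of two such steps. Among these compounds, this shows that, in these two pairs, the extra chain carbon gives a step within the scatter on both cores; it does not show that the change is without effect in general, and with only two pairs, which differ both in the core and in the place of the insertion along the chain, the contribution of the core cannot be separated from that of the chain length.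

The compounds shown leave open how 4-(dimethylamino)butyl reads on the core of compound 1, and whether a chain longer than 4-(dimethylamino)butyl would still give a step within the scatter. They also leave open what a different amine, such as diethylamino in place of dimethylamino, or a carboxylic acid at the chain end would give on either core.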